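A few compounds are considered here, and "the series" means these few. Any claim that something is new, unique, unknown or untested is made for them only; others in the source may bear on it.

Measured so far in a functional assay on COR-L23 cells (Homo sapiens) for antiproliferative activity, read by CellTiter-Glo, with a stated time of 72 h; a higher number here means a weaker inhibitor, a lower number a stronger inhibitor:
compound 1 `C[C@H](NC(=O)[C@@H]1CCCN1C)c1ccc(NC(=O)N2CC(c3cccnc3)C2)cc1` gives 38 nM
compound 2 `CCC(=O)N[C@@H](C)c1ccc(NC(=O)N2CC(c3cccnc3)C2)cc1` gives 120 nM
compound 3 `C[C@H](NC(=O)[C@@H]1CCCN1C)c1ccc(NC(=O)N2CC(c3ccc(N)nc3)C2)cc1` gives 41 nM

Compound 4 `CCC(=O)N[C@@H](C)c1ccc(NC(=O)N2CC(c3ccc(N)nc3)C2)cc1` has not yet been measured in this assay.

Compounds 1 and 2 share one core and differ in a single place: ethyl in place of 1-methylpyrrolidin-2-yl on a carbonyl carbon. That change gave a 3.2-fold higher number from compound 1 to compound 2 (0.50 log units; beyond the scatter), a modest loss of potency.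

Compounds 3 and 4 share a second core, which differs from the first by amino in place of hydrogen on an aromatic carbon. That difference on its own made almost no difference: a 1.1-fold higher number from compound 1 to compound 3 (0.03 log units; within the scatter).

The change from compound 3 to compound 4 is the same one, (ethyl in place of 1-methylpyrrolidin-2-yl on a carbonyl carbon), and it sits in an identical surrounding, so it can be counted as the same change, now made on the second core.

The step from compound 3 to compound 4 is expected to be a 3.2-fold higher number from compound 3 to compound 4 (0.50 log units; beyond the scatter). This expectation rests on the measured 3.2-fold higher number from compound 1 to compound 2 (0.50 log units; beyond the scatter) together with the near-neutral a 1.1-fold higher number from compound 1 to compound 3 (0.03 log units; within the scatter), which suggests the second core responds much like the first. Compound 4 is therefore estimated at 130 nM, with a plausible range from 60 nM to 280 nM.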

Compound 4, half-maximal inhibitory concentration: 120 nM
Estimate against measurement, compound 4: 1.1-fold (0.03 log units) above; measured number inside the range.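

In this assay, putting ethyl in place of 1-methylpyrrolidin-2-yl on the carbonyl carbon gave a 2.9-fold higher number from compound 3 to compound 4 (0.47 log units; beyond the scatter), which matches the earlier step on the core of compound 1: the same change on two cores in this assay, a 3.2-fold higher number (0.50 log units; beyond the scatter) from compound 1 to compound 2 and a 2.9-fold higher number (0.47 log units; beyond the scatter) from compound 3 to compound 4, 1.1-fold (0.03 log units) apart, within the scatter of two such steps. Read the other way, amino in place of hydrogen on an aromatic carbon gave no change at the digits printed from compound 2 to compound 4 (within the scatter), and it made no difference that can be told from the scatter with either group on the carbonyl carbon: the same change on two cores in this assay, a 1.1-fold higher number (0.03 log units; within the scatter) from compound 1 to compound 3 and no change at the digits printed (within the scatter) from compound 2 to compound 4, 1.1-fold (0.03 log units) apart, within the scatter of two such steps. Across these four compounds the two changes therefore act independently, so the step carries from one core to the other, but this rests on a single pair of cores in one cell assay and does not show why the number rises or that the step would carry to any other core.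

Still open, as far as these compounds go, is whether a longer chain or a simple amine on the carbonyl carbon would behave the same way on both cores. From the compounds shown here alone, it is equally open whether a methoxy group or a carboxylic acid in place of the amino group would leave the step intact.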